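This account rests on a few compounds, and the source may have more. Where it says the series, first, only, none or still open, it means among the compounds named here.

Working notes on the series. Compound 1 `CN(C)CCCOc1ccc(CN(C)c2nc3ccc(Oc4ccc(C(F)(F)F)cc4)cc3s2)cc1` and compound 2 `CN(Cc1ccc(OCCCNC(=N)N)cc1)c1nc2ccc(Oc3ccc(C#N)cc3)cc2s1` share a core and differ in the chain ending and in the substituent on the outer aryl ether. In an assay on cells for inhibition of Voltage-dependent T-type calcium channel subunit alpha-1H (Homo sapiens), read by FLIPR and calcium flux, with stated times of 600 s and 300 s (on this read-out higher numbers stand for weaker inhibition and lower numbers for stronger inhibition), compound 1 gives 54000 nM. In this assay compound 2 gives 153000 nM, the highest number of the two, and the gap to compound 1 lies beyond the scatter.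

Compound 3 `CN(C)CCCOc1ccc(CN(C)c2nc3ccc(Oc4ccc(C#N)cc4)cc3s2)cc1` is not yet measured in this assay. Going by the values given here, it differs from compound 2 by a group of 3 heavy atoms (2 carbon, 1 nitrogen; no ring) in place of a group of 4 heavy atoms (1 carbon, 3 nitrogen; no ring), on a saturated chain carbon, three bonds along the chain from an oxygen on an aromatic ring, so that the chain ending becomes the one carried by compound 1, while the nitrile on the outer ring stays as in compound 2. Among the compounds with values here, no measured step isolates this change. The expected step from compound 2 to compound 3 is a 2.6-fold lower number from compound 2 to compound 3 (0.41 log units; beyond the scatter), toward stronger inhibition, because compound 1, which carries the same dimethylamino chain ending, gives 54000 nM. Compound 3 is estimated at 60000 nM, within 25000 nM to 150000 nM.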

Compound 3, half-maximal inhibitory concentration: 64000 nM
The estimate for compound 3 lay 1.1-fold (0.03 log units) below the measured number; low and high end bracket the measured number.
By their numbers in this assay, from the lowest: compounds 1 and 3 (each within the scatter of the next); then compound 2.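

In this assay, dimethylamino in place of the group carried by compound 2, on a saturated chain carbon, three bonds along the chain from an oxygen on an aromatic ring, gives a 2.4-fold lower number from compound 2 to compound 3 (0.38 log units; beyond the scatter). Going by these compounds alone, this is the first isolated step at this position: a modest one toward stronger inhibition, with the nitrile held constant. With the dimethylamino chain ending held constant, cyano in place of trifluoromethyl on an aromatic carbon gives a 1.2-fold higher number from compound 1 to compound 3 (0.07 log units; within the scatter), so of the two single changes only the one at the chain ending moves the number beyond the scatter, and nothing shown gives a reason for either step.

On these data alone, whether a primary amine, a morpholine or a carboxylic acid at the chain ending would shift the number further remains open. As far as these compounds go, a longer chain and a chlorine on the outer ring also remain open.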